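This account rests on a few compounds, and the source may have more. Where it says the series, first, only, none or still open, it means among the compounds named here.

Working notes on a short ester series in a functional assay on the whole organism (strain Sprague-Dawley CD) for inhibition, with Rattus norvegicus as the target, read by paw edema, at a dose of 10 mg/kg by the intraperitoneal route; a higher number here means a stronger effect of the compound at the dose given, a lower number a weaker effect.

For the measured compounds named here, compound 2 (`CC(C)OC(=O)C(=O)Nc1cccccc1=O`) gives 76% in this assay and stands highest of the two numbers measured so far. The nearest value belongs to compound 1 (`CCOC(=O)C(=O)Nc1ccccc(OC)c1=O`), which gives 24% in this assay, a gap beyond the usual scatter. Going by the values given here, compound 1 and compound 2 differ in more than one place, so no single step between them is counted; the two values are taken as they stand.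

Compound 3 (`O=C(O)COC(=O)C(=O)Nc1cccccc1=O`) is the unmeasured member. Against compound 2 the change is: carboxymethyl in place of isopropyl on an oxygen next to a carbonyl group. The change sits on an oxygen next to a carbonyl group, the isopropyl of compound 2 being replaced.

Among the compounds with values here, no measured pair follows a step of this kind, so the expectation rests on compound 2 alone, whose value of 76% in this assay is the starting point. A fall beyond the scatter is expected, the step of a number 31 percentage points lower from compound 2 to compound 3 (beyond the scatter) being the estimated size and direction. Compound 3 is estimated at 45% in this assay, within a range from 15% to 75%.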

Compound 3, a percentage reported as inhibition, in the whole organism at one dose (the size of the read-out at that dose, not a potency): 66%
Compound 3: middle estimate off by 21 percentage points, on the low side; the measured number falls inside the stated range.
By their numbers in this assay, from the lowest: compound 1; then compounds 3 and 2 (each within the scatter of the next).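

On an oxygen next to a carbonyl group, carboxymethyl in place of isopropyl gives in this assay a number 10 percentage points lower from compound 2 to compound 3 (within the scatter), so this change does not separate the two compounds at the dose given. For the compounds shown here, this is the first single-place step, and it shows that the isopropoxy to carboxymethoxy change, which brings in a hydrogen-bond donor and a hydrogen-bond acceptor, leaves no difference beyond the usual scatter in this read-out. Nothing measured bears on why the two compounds cannot be told apart here.

The compounds shown leave open whether the same tolerance extends to other groups at this oxygen, such as a longer alkyl chain, an aminoethyl group or the free carboxylic acid with no ester at all. Compound 1 differs from compound 2 and compound 3 in more than one place, so the separate contributions of its ethyl ester and its methoxy group remain unresolved, and a single dose gives no potency for any of the three.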